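The compounds below may be only part of what the source reports. "The series", "measured", "known", "first", "only" and "open" are said of these compounds alone.

In an ADME assay on MT4 cells (Homo sapiens) for cytotoxicity, read by MTT assay, with a stated time of 5 days (on this read-out higher numbers stand for lower toxicity in this test and lower numbers for higher toxicity in this test), compound 1 , whose structure is `O=C(CSc1snnc1-c1ccc(Br)cc1Br)Nc1ccccc1Cl`, gives only a limit of the assay in the form > 240000 nM and no number. Two other compounds have numbers: compound 2 (`Cc1ccc(NC(=O)CSc2snnc2-c2ccc(Br)cc2Br)cc1`) gives in this assay 24000 nM, and compound 3 (`Cc1ccc2sc(NC(=O)CSc3snnc3-c3ccc(Br)cc3Br)nc2c1`) gives in this assay 23600 nM. Going by the values given here, the single measured step with one change is an at least 10-fold lower number from compound 1 to compound 2 (1.00 log units; beyond the scatter); it replaces the whole ring on the amide-type nitrogen and so tells little about a change of one halogen on that ring.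

Compound 4 (`O=C(CSc1snnc1-c1ccc(Br)cc1Br)Nc1ccccc1Br`) differs from compound 1 in one place: bromo in place of chloro on an aromatic carbon. Among the compounds with values here, no measured step matches this change, and the starting point is itself a limit, as stated in the limit of > 240000 nM in this assay, at which 1 of the 3 values shown sits, for this assay. The expectation is therefore no step beyond the scatter in this assay, with the result of compound 4 most likely sitting again at the limit. The estimated value for compound 4 is 240000 nM, with a range from 100000 nM to 500000 nM, which means an expected step of a number no higher from compound 1 to compound 4 (the limit leaves the size open).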

Compound 4, half-maximal cytotoxic concentration: > 221000 nM
Compound 4: no number, only a limit; the forecaster's own chance of this, stated with the estimate: 60%; the middle value is on the limit's open side.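

In this assay compound 4 gives a limit and not a number: the limit of > 221000 nM in this assay, at which 1 of the 4 values shown sits.

Compound 1 also gives only a limit, so the step from chloro to bromo on this aromatic carbon cannot be read, and the two halogens cannot be ranked. What is new comes from the comparison with the 4-methylphenyl compound: 2-bromophenyl in place of 4-methylphenyl gives an at least 9.2-fold higher number from compound 2 to compound 4 (0.96 log units; beyond the scatter), beyond the scatter, and this mirrors an at least 10-fold lower number from compound 1 to compound 2 (1.00 log units; beyond the scatter), so both ortho-halogenated rings shown stand apart from the 4-methylphenyl ring in the same direction.

The compounds shown do not separate the part played by the methyl group from the part played by where a group sits on the ring, since compound 2 changes both at once. They also leave open what a 2-fluorophenyl ring, or an amine or a carboxylic acid on this ring, would give.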